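The source may hold more compounds than are shown below. What is called first, only, known or untested is meant among the compounds shown, and "the series" means these compounds.

Among the measured compounds shown here, in a functional assay on MCF7 cells (Homo sapiens) for cytotoxicity, read by MTT assay, with a stated time of 96 h (on this read-out lower numbers stand for stronger inhibition and higher numbers for weaker inhibition), compound 1 `COc1cc(C(=O)c2cn(-c3ccccc3)cc2-c2ccccc2Cl)cc(OC)c1OC` gives 76 nM and compound 2 `COc1cc(C(=O)c2cn(-c3cccc(N)c3)cc2-c2ccccc2Cl)cc(OC)c1OC` gives 40 nM, so compound 2 stands within the scatter of the only other measured compound. Compound 3 `COc1cc(C(=O)c2cn(-c3cccc(N)c3)cc2-c2cccc(N)c2)cc(OC)c1OC` departs from compound 2 by 3-aminophenyl in place of 2-chlorophenyl on an aromatic carbon. For the measured compounds named here, only one measured step bears on this change, and only loosely: a 1.9-fold lower number from compound 1 to compound 2 (0.28 log units; within the scatter), with amino in place of hydrogen on an aromatic carbon. That step lies within the scatter, but it leaves the 2-chlorophenyl group untouched. The data therefore contain no direct test of replacing this group, and the range must stay wide. No change beyond the scatter is expected, and the expected step is a 1.5-fold higher number from compound 2 to compound 3 (0.18 log units; within the scatter). In this assay compound 3 is estimated at 60 nM, with an expected range of 15 nM to 300 nM.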

Compound 3, half-maximal inhibitory concentration: 60 nM
Estimate against measurement, compound 3: no gap at the digits printed; the measured number falls inside the stated range.
By their numbers in this assay, from the lowest: compounds 2, 3 and 1 (each within the scatter of the next).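

In this assay, a 1.5-fold higher number from compound 2 to compound 3 (0.18 log units; within the scatter), the first direct test at this position, so compound 2 and compound 3 cannot be told apart. On this background, with a 3-aminophenyl group on the ring nitrogen, the 2-chlorophenyl group on this aromatic carbon can thus give way to 3-aminophenyl without a step beyond the scatter; this holds for this one pair only. No measured evidence bears on why the two groups read alike here.

As far as these compounds go, whether the same holds with a plain phenyl on the ring nitrogen stays open, as does the reading of an amino group at other places on this phenyl ring. Also open, from the compounds shown here alone, is how far this position tolerates groups other than substituted phenyl rings, such as a methyl group, or a phenyl ring carrying a hydroxyl or a carboxylic acid.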